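Amino-bearing sulfur substituent: expected step to compound 4

The source may hold more compounds than are shown below. What is called first, only, known or untested is meant among the compounds shown, and "the series" means these compounds.

In a functional assay on HT cells (Homo sapiens) for antiproliferative activity, read by fluorescence, with a stated time of 72 h (a lower number here means a stronger inhibitor of growth, a higher number a weaker inhibitor of growth), compound 1 `CC(C)c1n[nH]c2c(NCc3ccc(-c4ccccn4)cc3)nc(SCC(C)(C)O)nc12` gives 507 nM, compound 2 `CC(C)c1n[nH]c2c(NCc3ccc(-c4ccccn4)cc3)nc(SCC(C)(C)N)nc12` gives 85 nM and compound 3 `COCSc1nc(NCc2ccc(-c3ccccn3)cc2)c2[nH]nc(C(C)C)c2n1` gives 340 nM. Compound 3 therefore stands level with compound 1, as a 1.5-fold lower number from compound 1 to compound 3 (0.17 log units; within the scatter) shows, while a 4.0-fold higher number from compound 2 to compound 3 (0.60 log units; beyond the scatter) separates it from compound 2.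

Compound 4 `CC(C)c1n[nH]c2c(NCc3ccc(-c4ccccn4)cc3)nc(SC3CCCCC3N)nc12` has 2-aminocyclohexyl in place of methoxymethyl on a sulfur. Among the compounds with values here, two measured steps bear on this change. Swapping hydroxy for amino gives a 6.0-fold lower number from compound 1 to compound 2 (0.78 log units; beyond the scatter), and the step that removes the amino-bearing chain gives a 4.0-fold higher number from compound 2 to compound 3 (0.60 log units; beyond the scatter). Both are modest, and both favour the amino-bearing compound 2. Within the data shown here, that rests on a single amino example, and no measured compound carries a ring on the sulfur, so the guide is loose. A modest move to a lower number is expected, close in size to the gap between compound 3 and compound 2. The expected change is a 3.1-fold lower number from compound 3 to compound 4 (0.49 log units; beyond the scatter). Compound 4 is estimated at 110 nM, with an expected range of 40 nM to 300 nM.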

Compound 4, concentration for 50% growth inhibition: 139 nM
The estimate for compound 4 lay 1.3-fold (0.10 log units) below the measured number, and the stated range covers the measured number.
By their numbers in this assay, from the lowest: compounds 2 and 4 (each within the scatter of the next); then compounds 3 and 1 (each within the scatter of the next).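

On the sulfur, 2-aminocyclohexyl in place of methoxymethyl gives a lower number in this assay (a 2.4-fold lower number from compound 3 to compound 4 (0.39 log units; beyond the scatter)), and the same holds against the hydroxy-bearing chain (a 3.6-fold lower number from compound 1 to compound 4 (0.56 log units; beyond the scatter)), so an amino-bearing group that includes a six-membered ring of carbon only also sits on the low side. The ring does not separate compound 4 from the open-chain amine (a 1.6-fold higher number from compound 2 to compound 4 (0.21 log units; within the scatter)), and among these four compounds the two amino-bearing groups lie lower than the two without an amino group, with none going against this. No supporting measurement bears on the cause of these steps.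

Plain cyclohexyl on the sulfur would show how much of the step depends on the amino group rather than the ring. Also open, going by these compounds, are a dimethylamino group in place of the amino group, 2-aminocyclopentyl as a smaller ring, and 3-aminopropyl as a longer chain.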